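A few compounds are considered here, and "the series" means these few. Any claim that something is new, unique, unknown or untested is made for them only; others in the source may bear on it.

Measured compounds:
- compound 1 `COc1ccc(-c2cn3ccnc3c(-c3ccc4ncn(C5CCCCC5)c4c3)n2)cc1`: 98.6%
- compound 2 `CC(=O)c1ccc(-c2cn3ccnc3c(-c3ccc4ncn(C5CCCCC5)c4c3)n2)cc1`: 2.65%

In a functional assay on HL-60 cells (Homo sapiens) for inhibition, read by sulforhodamine B assay, with a stated time of 48 h, tested at 10 uM (a lower number here means less inhibition, a higher number more inhibition at the concentration tested (going by the name of the read-out)), compound 2 gives 2.65%, the lowest of the two numbers, while compound 1 gives 98.6%. For the measured compounds named here, the only measured step, a number 96 percentage points lower from compound 1 to compound 2 (beyond the scatter), shows that changing the group at this position can move the read-out strongly. Compound 3 `c1csc(-c2cn3ccnc3c(-c3ccc4ncn(C5CCCCC5)c4c3)n2)c1` carries a different change at the same place: thiophen-2-yl in place of 4-acetylphenyl on an aromatic carbon. Going by the values given here, no measured step involves thiophen-2-yl, so the direction is uncertain, and a step of a number 47.4 percentage points higher from compound 2 to compound 3 (beyond the scatter) is expected only loosely. Compound 3 is estimated at 50%, within 5% to 95%.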

Compound 3, a percentage reported as inhibition, at one concentration (the size of the read-out at that concentration, not a potency): 26.6%
Beside the measured number, compound 3's estimate is 23.4 percentage points above it; low and high end bracket the measured number.
By their numbers in this assay, from the lowest: compound 2; then compound 3; then compound 1.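

In this assay, thiophen-2-yl gives an intermediate result: a number 24 percentage points higher from compound 2 to compound 3 (beyond the scatter), yet a number 72 percentage points lower from compound 1 to compound 3 (beyond the scatter). This position therefore does not act as a simple on-off switch, since a five-membered aromatic ring with one sulfur atom retains only part of the inhibition seen with 4-methoxyphenyl. No available evidence explains these differences. On these data alone, it remains open whether a phenyl ring carrying an amine or a carboxylic acid, or a non-aromatic ring such as morpholine, would come closer to compound 1 or to compound 2.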